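Cyclic Sulfonamide in Place of the Dimethylamide

The compounds below may be only part of what the source reports. "The series", "measured", "known", "first", "only" and "open" are said of these compounds alone.

Of the compounds shown here, three on the shared core have numbers so far. Compound 1 `CNCc1ccccc1Oc1ccc(OC)cc1Cl` gives 5950 nM in an assay on HEK293 cells for inhibition of sodium-dependent dopamine transporter (Homo sapiens); on this read-out lower numbers stand for stronger inhibition and higher numbers for weaker inhibition. Compound 2 `CNCc1cc(C#N)ccc1Oc1ccc(Cl)cc1Cl` gives 3010 nM in this assay, and compound 3 `CNCc1cc(C(=O)N(C)C)ccc1Oc1ccc(Cl)cc1Cl` gives 275 nM. Among the compounds with values here, compound 3 thus stands at the lowest number of the three, and its distance from compound 2 comes from a single exchange: the step of an 11-fold lower number from compound 2 to compound 3 (1.04 log units; beyond the scatter) is the only one-place step among the measured compounds, and it is large.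

Compound 4 `CNCc1cc(N2CCCS2(=O)=O)ccc1Oc1ccc(Cl)cc1Cl` differs from compound 3 by a group of 7 heavy atoms (3 carbon, 1 nitrogen, 2 oxygen, 1 sulfur; one five-membered non-aromatic ring with 2 hetero atoms) in place of a group of 5 heavy atoms (3 carbon, 1 nitrogen, 1 oxygen; no ring), on an aromatic carbon. Within the data shown here, no measured step covers this exact exchange. The step that bears on it is an 11-fold lower number from compound 2 to compound 3 (1.04 log units; beyond the scatter), which shows that the group sitting meta to the (methylamino)methyl group can shift the number strongly, though it says nothing about whether the new ring will do so. Among the measured compounds shown here, with no direct precedent, the step of a 1.2-fold higher number from compound 3 to compound 4 (0.07 log units; within the scatter) is expected to stay modest. Compound 4 is therefore estimated at 320 nM, with a range from 80 nM to 1300 nM.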

Compound 4, half-maximal inhibitory concentration: 138 nM
Estimate against measurement, compound 4: 2.3-fold (0.37 log units) above; the range from low to high includes it.
By their numbers in this assay, from the lowest: compounds 4 and 3 (each within the scatter of the next); then compounds 2 and 1 (each within the scatter of the next).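

The step of a 2.0-fold lower number from compound 3 to compound 4 (0.30 log units; within the scatter) in this assay shows that the cyclic sulfonamide and dimethylcarbamoyl cannot be told apart at this position, meta to the (methylamino)methyl group. The step of a 22-fold lower number from compound 2 to compound 4 (1.34 log units; beyond the scatter) then gives a second large change away from cyano, alongside an 11-fold lower number from compound 2 to compound 3 (1.04 log units; beyond the scatter), so the large drop at this position is not confined to dimethylcarbamoyl. Nothing available explains either step.

The compounds shown leave open whether the ring itself matters, since an open-chain methanesulfonamide or a six-membered cyclic sulfonamide at this position would be needed to separate the ring from the sulfonyl group. They also leave open how a simple amine or a carboxylic acid at this position would compare with cyano and with these two groups.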